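The source may report more compounds than this note shows. Statements on the series, on what has been measured and on what is new or still open speak of the compounds shown alone.

Compound 1 `NC1=NC2(CCSCC2)N(OCCCOc2cccc(Cl)c2)C(N)=N1`, tested in an assay on isolated protein for inhibition of Dihydrofolate reductase (Homo sapiens), read by spectrophotometry, using NADPH, with stated times of 5 s and 6 min, tested at 50 uM (a lower number here means a weaker effect, a higher number a stronger effect of the compound at the concentration tested), gives 88.8%. Compound 2 `NC1=NC2(CCOCC2)N(OCCCOc2ccccc2Br)C(N)=N1` in this assay gives 85%, a value within the scatter of compound 1, so the two cannot be ordered. For compound 3 `COc1ccc(OCCCON2C(N)=NC(N)=NC23CCOCC3)cc1` the result in this assay is "not determined" (no result reported). Compound 4 `NC1=NC2(CCSCC2)N(OCCCOc2cc(Cl)c(Cl)cc2Cl)C(N)=N1` has not yet been measured. It differs from compound 1 in one place: 2,4,5-trichlorophenyl in place of 3-chlorophenyl on an oxygen on a saturated carbon. Within the data shown here, no measured pair isolates this change, so its size cannot be read from the data. The step of a number 0.8 percentage points lower from compound 1 to compound 4 (within the scatter) is expected to stay within the usual scatter because compound 1 already gives 88.8%, leaving little room upward. Compound 4 is therefore estimated at 88%, within a range from 74% to 96%.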

Compound 4, a percentage reported as inhibition, at one concentration (the size of the read-out at that concentration, not a potency): 94.4%
Estimate against measurement, compound 4: 6.4 percentage points below; low and high end bracket the measured number.
By their numbers in this assay, from the lowest: compounds 2, 1 and 4 (each within the scatter of the next).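

In this assay, putting 2,4,5-trichlorophenyl in place of 3-chlorophenyl on an oxygen on a saturated carbon gives a number 5.6 percentage points higher from compound 1 to compound 4 (within the scatter), so this position tolerates the trichlorinated ring with no change that can be told from scatter. The read-out comes from one concentration and is not a potency, so any difference in potency between the two compounds remains unseen. Nothing at hand bears on the reason for this result. Still open, going by these compounds, is how the read-out would respond to an amine or a carboxylic acid on this aromatic ring, or to a longer chain in place of the present one.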